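Pyridyl attachment change on the shared core

The compounds below may be only part of what the source reports. "The series", "measured", "known", "first", "only" and "open" are said of these compounds alone.

Measured compounds:
compound 1 `O[C@@H](c1ccccc1)[C@H]1CO[C@H](c2ccccc2)[C@@H](C/C=C/c2ccncc2)C1` — a functional assay on HeLa cells (Homo sapiens) for cytotoxicity, read by WST assay, with a stated time of 48 h; a higher number here means a weaker inhibitor, a lower number a stronger inhibitor: > 100000 nM
compound 2 `COc1ccc([C@H](O)[C@H]2CO[C@H](c3ccc(OC)c(OC)c3)[C@@H](C/C=C/c3ccc(OC)c(OC)c3)C2)cc1` — this assay : 46000 nM

Compound 1 stands at the edge of what this assay reports: its reading > 100000 nM is a limit of the assay and not a number, as the evidence the limit of > 100000 nM in this assay, at which 1 of the 2 values shown sits, records. Within the data shown here, compound 2 is the only compound with a numerical value in this assay, and compound 2 gives 46000 nM. Among the measured compounds shown here, compound 1 and compound 2 differ in several places, so no single step between measured compounds can be drawn from them.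

Compound 3 `O[C@@H](c1ccccc1)[C@H]1CO[C@H](c2ccccc2)[C@@H](C/C=C/c2cccnc2)C1` has not been measured yet. It differs from compound 1 in one place only: pyridin-3-yl in place of pyridin-4-yl on a double-bonded chain carbon bound to a double-bonded chain carbon. The step from compound 1 to compound 3 in this assay is expected to be small, within the scatter and with no set direction, as in a number no higher from compound 1 to compound 3 (the limit leaves the size open). Compound 3 is therefore expected to give about 100000 nM, with a range from 30000 nM to 300000 nM, most likely reported again as a limit.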

Compound 3, half-maximal inhibitory concentration: > 100000 nM
Compound 3 ended at the assay's limit; the forecaster's own chance of this, stated with the estimate: 70%; the middle value lies on the limit itself.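

In this assay, among these compounds, compound 1 and compound 3 both read as limits of the assay and not as numbers, so no step between them can be read: the limit of > 100000 nM in this assay, at which 2 of the 3 values shown sit.

Left open: whether pyridin-3-yl in place of pyridin-4-yl changes the reading at all on the shared core.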